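The source may report more compounds than this note shows. Statements on the series, on what has been measured and on what is new or still open speak of the compounds shown alone.

Compound 1 `Cn1ncc2cc(-c3cnc4[nH]ccc4c3N3CCC4(CCNC4=O)CC3)ccc21` — in an assay on cells for binding affinity to Cyclin-C/Cyclin-dependent kinase 19 (Homo sapiens), read by LanthaScreen (on this read-out higher numbers stand for weaker inhibition and lower numbers for stronger inhibition), compound 1 gives 7 nM.
Compound 2 `Cn1ncc2cc(-c3cnc4[nH]cnc4c3N3CCC4(CCNC4=O)CC3)ccc21` — in this assay compound 2 gives 5 nM.

These two numbers sit within the usual scatter of each other, so compound 1 is not set apart from compound 2 on this read-out; both are low numbers, meaning strong inhibition. Compound 3 `O=C1NCCC12CCN(c1c(-c3ccc4ncsc4c3)cnc3[nH]ccc13)CC2` has not yet been measured. It differs from compound 1 in one place: 1,3-benzothiazol-6-yl in place of 1-methyl-1H-indazol-5-yl on an aromatic carbon. The group that leaves and the group that enters are both two-ring aromatic systems of close to the same size, each with no hydrogen-bond donor and two hydrogen-bond acceptors. Among the measured compounds shown here, no measured pair shows this kind of exchange, so the size of the step is uncertain. The expectation is a modest move toward a higher number, a 2.1-fold higher number from compound 1 to compound 3 (0.33 log units; beyond the scatter), possibly not beyond the scatter. Compound 3 is estimated at 15 nM, in a range from 5 nM to 50 nM.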

Compound 3, half-maximal inhibitory concentration: 80 nM
Beside the measured number, compound 3's estimate is 5.3-fold (0.73 log units) below it; the measured number lies above the stated range.
By their numbers in this assay, from the lowest: compounds 2 and 1 (each within the scatter of the next); then compound 3.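

In this assay, among the compounds shown here, the aromatic carbon carrying this two-ring group proves far less forgiving than the earlier compounds could show: putting 1,3-benzothiazol-6-yl in place of 1-methyl-1H-indazol-5-yl gives an 11-fold higher number from compound 1 to compound 3 (1.06 log units; beyond the scatter), a large step. The two groups match in their ring types and in their counts of hydrogen-bond donors and acceptors and differ little in size, so those counts alone do not make them interchangeable at this position. No measurement here accounts for the size of the step.

The compounds shown leave open which difference between the two groups carries the step, the sulfur or the methyl on the indazole nitrogen among them. They also leave open how a single-ring group such as phenyl or pyridyl would fare at this position, and whether the same exchange on the core of compound 2 gives a similar step.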